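Anilide Variation at the Amide of a Vitamin D Receptor Agonist Series

The source may report more compounds than this note shows. Statements on the series, on what has been measured and on what is new or still open speak of the compounds shown alone.

Compound 3 (`CCn1c(C(=O)N(C)c2ccccc2)ccc1C(CC)(CC)c1ccc(OCC(O)C(C)(C)C)c(C)c1`) gives 6400 nM in an assay on HL-60 cells for agonist activity at vitamin D3 receptor (Homo sapiens), read by microscopy, with a stated time of 96 h (on this read-out lower numbers stand for an effect already at smaller amounts and higher numbers for an effect only at larger amounts of compound), the highest of the three numbers. Compound 1 (`CCn1c(C(=O)NCCN(C)C)ccc1C(CC)(CC)c1ccc(OCC(O)C(C)(C)C)c(C)c1`) gives 14 nM and compound 2 (`CCn1c(C(=O)NCCCN(C)C)ccc1C(CC)(CC)c1ccc(OCC(O)C(C)(C)C)c(C)c1`) gives 37 nM in this assay. Compound 4 (`CCn1c(C(=O)Nc2ccc(OC(F)(F)F)cc2)ccc1C(CC)(CC)c1ccc(OCC(O)C(C)(C)C)c(C)c1`) carries (4-(trifluoromethoxy)phenyl)amino in place of methyl(phenyl)amino on a carbonyl carbon. For the measured compounds named here, no measured pair shows this change; the nearest steps, a 460-fold higher number from compound 1 to compound 3 (2.66 log units; beyond the scatter) and a 170-fold higher number from compound 2 to compound 3 (2.24 log units; beyond the scatter), only show that moving from a dimethylamino-chain amide to methyl(phenyl)amino was large, and both leave the change to compound 4 untested. Compound 4 is therefore expected to stay in the range of compound 3, with a step of a 2.1-fold lower number from compound 3 to compound 4 (0.33 log units; beyond the scatter) expected. Compound 4 is estimated at 3000 nM, between 300 nM and 20000 nM.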

Compound 4, half-maximal effective concentration: > 50000 nM
Compound 4: only a limit was reported (the forecaster's own chance of this, stated with the estimate: 15%); middle value at least 16-fold (1.22 log units) from the limit.
By their numbers in this assay, from the lowest: compound 1; then compound 2; then compound 3. At a limit, above all of these: compound 4.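

Compound 4 gives only a limit, not a number: the limit of > 50000 nM in this assay, at which 1 of the 4 values shown sits. Placing (4-(trifluoromethoxy)phenyl)amino on the carbonyl carbon instead of methyl(phenyl)amino gives an at least 7.8-fold higher number from compound 3 to compound 4 (0.89 log units; beyond the scatter), so an aromatic amide can sit further from the chain amides than compound 3 showed. The gap to those chain amides widens to an at least 1300-fold higher number from compound 2 to compound 4 (3.13 log units; beyond the scatter) and an at least 3500-fold higher number from compound 1 to compound 4 (3.55 log units; beyond the scatter).

This step removes the methyl and adds the trifluoromethoxy group together, so the compounds shown do not separate the two. On these data alone, how a plain phenylamino group would read remains open.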